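The compounds below may be only part of what the source reports. "The series", "measured", "known", "first", "only" and "open" are said of these compounds alone.

Compounds and values

Compound 1 (`O=C(Cn1cc(CO)nn1)NCc1ccccc1`) 490 uM
Compound 2 (`CCC(O)Cc1cn(CC(=O)NCc2ccccc2)nn1`) 630 uM
Compound 3 (`CC(C)(O)c1cn(CC(=O)NCc2ccccc2)nn1`) 1600 uM
Compound 4 (`O=C(Cn1cc(C(=O)O)nn1)NCc1ccccc1`) not yet measured

All of these numbers come from an ADME assay on cells (spleen, Mus musculus, strain C57BL/6) for inhibition, read by flow cytometry and propidium iodide staining, with a stated time of 24 h, at 37 degrees C (on this read-out lower numbers stand for an effect already at smaller amounts and higher numbers for an effect only at larger amounts of compound), and compound 3 stands highest of the three measured compounds. The move to compound 4 puts carboxy in place of 1-hydroxy-1-methylethyl on an aromatic carbon. Two measured steps lead into the same place on the shared core. They are a 3.3-fold higher number from compound 1 to compound 3 (0.51 log units; beyond the scatter) and a 2.5-fold higher number from compound 2 to compound 3 (0.40 log units; beyond the scatter) and both are modest. The third, a 1.3-fold higher number from compound 1 to compound 2 (0.11 log units; within the scatter) stays within the scatter. Within the data shown here, no measured compound carries carboxy, so these steps offer only a rough guide to size. A modest step is therefore expected in this assay toward a lower number, in the direction of compound 1 at 490 uM and not beyond the span seen so far by much. The estimated change is a 2.0-fold lower number from compound 3 to compound 4 (0.30 log units; within the scatter) and it remains an expectation. For compound 4 the estimated value is 800 uM with an expected range from 300 uM to 2200 uM.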

Compound 4, concentration for half-maximal effect: "non-toxic" (no number reported)
Nothing numeric was reported for compound 4; no gap can be computed for the estimate.
By their numbers in this assay, from the lowest: compounds 1 and 2 (each within the scatter of the next); then compound 3.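

Among these compounds, compound 4 was reported only as "non-toxic", without a number, so no step from compound 3 at 1600 uM can be read. No available evidence bears on this result. The compounds shown leave open how carboxy compares numerically with 1-hydroxy-1-methylethyl at this place.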